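A few compounds are considered here, and "the series" means these few. Any claim that something is new, unique, unknown or untested is made for them only; others in the source may bear on it.

Measured in a functional assay on Jurkat cells (Homo sapiens) for cytotoxicity, read by MTT assay, with a stated time of 72 h; a lower number here means a stronger inhibitor, a higher number a weaker inhibitor:
- compound 1 `COC(=O)c1sc2c(C)cccc2c1Nc1cc(OC)c(OC)c(OC)c1`: 1630 nM
- compound 2 `COC(=O)c1sc2ccccc2c1Nc1cc(OC)c(OC)c(OC)c1`: 490 nM
- compound 3 `COC(=O)c1sc2cccc(C)c2c1Nc1cc(OC)c(OC)c(OC)c1`: 6710 nM

Compound 2, at 490 nM, has the lowest number of the three, and both of its gaps to the others lie beyond the scatter. Compound 4 `COC(=O)c1sc2ccc(C)cc2c1Nc1cc(OC)c(OC)c(OC)c1` is not yet measured. It differs from compound 2 by methyl in place of hydrogen on an aromatic carbon.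

Among the compounds with values here, two measured steps bear on this change, each exchanging the same hydrogen and methyl at a different aromatic carbon. The first is modest, a 3.3-fold lower number from compound 1 to compound 2 (0.52 log units; beyond the scatter), and it removes the methyl. The second is large, a 14-fold higher number from compound 2 to compound 3 (1.14 log units; beyond the scatter), and it adds one. In both, the compound with the methyl has the higher number, so a rise is expected in this assay here too. Its size is uncertain, since the two steps differ widely and the methyl of compound 4 occupies a third carbon.

The expected change is a 2.7-fold higher number from compound 2 to compound 4 (0.42 log units; beyond the scatter), closer in size to the modest step. For compound 4 the estimated value is 1300 nM, with an expected range of 350 nM to 5000 nM.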

Compound 4, half-maximal inhibitory concentration: 727 nM
Compound 4: the middle estimate sits 1.8-fold (0.25 log units) above what was measured; low and high end bracket the measured number.
By their numbers in this assay, from the lowest: compounds 2 and 4 (each within the scatter of the next); then compound 1; then compound 3.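

In this assay, methyl on this carbon, meta to a fused ring and para to a fused ring, gives a step within the scatter, a 1.5-fold higher number from compound 2 to compound 4 (0.17 log units; within the scatter), so compound 4 cannot be separated from compound 2. The same exchange of hydrogen and methyl therefore has no single size across the three carbons, since a 3.3-fold lower number from compound 1 to compound 2 (0.52 log units; beyond the scatter) and a 14-fold higher number from compound 2 to compound 3 (1.14 log units; beyond the scatter) both lie beyond the scatter, and compound 4 goes against any reading that methyl on this ring always raises the number. No measurement at hand accounts for the difference between the carbons.

What a longer chain such as propyl or an amine would do on this carbon stays open, as the compounds shown carry only hydrogen or methyl on this ring. Also open, from the compounds shown here alone, is whether this reading would hold with a carboxylic acid in place of the methyl ester.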